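The compounds below may be only part of what the source reports. "The series", "measured", "known", "first", "only" and "open" are said of these compounds alone.

Measured compounds in a functional assay on CHO cells for antagonist activity at Gonadotropin-releasing hormone receptor (Homo sapiens), read by a luciferase reporter, with a stated time of 30 min; a lower number here means a stronger inhibitor, a higher number a weaker inhibitor:

Compound 1 `CCOC(=O)c1cn(Cc2c(F)cccc2F)c2nc(-c3ccc(NC(=O)NCc4cn(CCN=[N+]=[N-])nn4)cc3)c(CN(C)Cc3ccccc3)n2c1=O`: 2570 nM
Compound 2 `CCOC(=O)c1cn(Cc2c(F)cccc2F)c2nc(-c3ccc(NC(=O)NCc4cn(CCOCCN=[N+]=[N-])nn4)cc3)c(CN(C)Cc3ccccc3)n2c1=O`: 3630 nM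
Compound 3 `CCNC(=O)Nc1ccc(-c2nc3n(Cc4c(F)cccc4F)cc(C(=O)NCc4cn(CCOCCOCCOCCN=[N+]=[N-])nn4)c(=O)n3c2CN(C)Cc2ccccc2)cc1`, a limit of the assay: < 10000 nM

Compound 1 and compound 2 differ by 2-azidoethoxy in place of azido on a saturated chain carbon, two bonds along the chain from an aromatic nitrogen. The measured step is a 1.4-fold higher number from compound 1 to compound 2 (0.15 log units; within the scatter). For compound 3 only a limit is known, (the limit of < 10000 nM in this assay, at which 1 of the 3 values shown sits). How the core of compound 1 and the core of compound 3 differ is not broken down here.

Compound 4 `CCNC(=O)Nc1ccc(-c2nc3n(Cc4c(F)cccc4F)cc(C(=O)NCc4cn(CCOCCOCCOCCOCCN=[N+]=[N-])nn4)c(=O)n3c2CN(C)Cc2ccccc2)cc1` has not been measured in this assay. It differs from compound 3 by 2-azidoethoxy in place of azido on a saturated chain carbon, two bonds along the chain from an oxygen on a saturated carbon. The surroundings of the place are not the same as between compound 1 and compound 2: there the saturated chain carbon sits two bonds along the chain from an aromatic nitrogen, here two bonds along the chain from an oxygen on a saturated carbon. The change is therefore the same kind of change, not the same change.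

For compound 4 the step that the limit leaves unreadable from compound 3 to compound 4 is expected. That expectation rests on the measured step of a 1.4-fold higher number from compound 1 to compound 2 (0.15 log units; within the scatter), which stayed within the scatter, and on the limit of compound 3. Compound 4 is estimated at 5000 nM, with a range from 1500 nM to 10000 nM; a limit rather than a number is quite possible.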

Compound 4, half-maximal inhibitory concentration: < 10000 nM
Compound 4: no number, only a limit; the forecaster's own chance of this, stated with the estimate: 55%; the middle value does not contradict the limit.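

Compound 4, like compound 3, gives only a limit in this assay, and no step from compound 3 to compound 4 can be read: the limit of < 10000 nM in this assay, at which 2 of the 4 values shown sit.

The compounds shown leave open where compound 3 and compound 4 actually stand, and whether 2-azidoethoxy in place of azido changes the read-out on the core of compound 3.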